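The compounds below may be only part of what the source reports. "The series", "measured", "known", "first", "only" and "open" are said of these compounds alone.

Compound 2 `Cc1cc(=O)oc2ccc(OCC(O)CN3CCCCC3)cc12` was measured in a functional assay on ileum for antagonist activity at histamine H1 receptor (Cavia porcellus), tested at 0.5 mg/mL; on this read-out lower numbers stand for an effect already at smaller amounts and higher numbers for an effect only at larger amounts of compound. In this assay, going by the values given here, compound 2 gives 0.0065 ug/mL, and the only other measured compound, compound 1 `CCN(CC)CC(O)COc1ccc2oc(=O)cc(C)c2c1`, gives 0.006 ug/mL in this assay; the step of a 1.1-fold higher number from compound 1 to compound 2 (0.03 log units; within the scatter) leaves the two within the scatter. Compound 3 `Cc1cc(=O)oc2ccc(OCC(O)CN3CCN(C)CC3)cc12` differs from compound 2 by 4-methylpiperazin-1-yl in place of piperidin-1-yl on a saturated chain carbon, two bonds along the chain from an oxygen on a saturated carbon. Among the compounds with values here, the single measured step, a 1.1-fold higher number from compound 1 to compound 2 (0.03 log units; within the scatter), replaced one amine with another at this same place without an effect beyond the scatter, so for compound 3 no change beyond the scatter is expected, a 1.2-fold higher number from compound 2 to compound 3 (0.09 log units; within the scatter). Compound 3 is therefore estimated at 0.008 ug/mL, with a range from 0.003 ug/mL to 0.025 ug/mL.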

Compound 3, half-maximal effective concentration: 0.006 ug/mL
The estimate for compound 3 lay 1.3-fold (0.12 log units) above the measured number, and the stated range covers the measured number.
By their numbers in this assay, from the lowest: compounds 1, 3 and 2 (each within the scatter of the next).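

Swapping piperidin-1-yl for 4-methylpiperazin-1-yl, which adds a second ring nitrogen and a second hydrogen-bond acceptor, gives a 1.1-fold lower number from compound 2 to compound 3 (0.03 log units; within the scatter) in this assay and, set against diethylamino, the same group gives no change at the digits printed from compound 1 to compound 3 (within the scatter) in this comparison too. This place on the chain has now carried three different amines, and all three values lie within the scatter of each other. Nothing measured here explains why these amines read alike. The compounds shown leave open how a morpholin-4-yl group, or a hydroxy group with no amine at all, would read at this place, and what a longer chain would do.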